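From iodo to thiophen-2-yl at the assay limit

A few compounds are considered here, and "the series" means these few. Any claim that something is new, unique, unknown or untested is made for them only; others in the source may bear on it.

Of the compounds shown here, three have been read so far, and none of them gives a number. In a functional assay on K562 cells (Homo sapiens), read by XTT assay, with a stated time of 48 h (on this read-out higher numbers stand for weaker inhibition and lower numbers for stronger inhibition), compound 1 (`COC(=O)c1nnn([C@@H]2O[C@H](CO)[C@H]3OC(C)(C)O[C@H]32)c1I`) returns only a limit, > 10000 nM as reported. Compound 2 (`CCOC(=O)c1nnn([C@@H]2O[C@H](COC(C)=O)[C@@H](OC(C)=O)[C@H]2OC(C)=O)c1I`) also returns only a limit, > 10000 nM as reported, so it has no exact place among the three. Compound 3 (`CCOC(=O)c1nnn([C@@H]2O[C@H](COC(C)C)[C@@H](OC(C)C)[C@H]2OC(C)C)c1-c1cccs1`) likewise ends at a limit, > 10000 nM as reported. The whole picture in this assay is the limit of > 10000 nM in this assay, at which 3 of the 3 values shown sit, and no order of potency can be drawn from it.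

Compound 4 (`CCOC(=O)c1nnn([C@@H]2O[C@H](COC(C)=O)[C@@H](OC(C)=O)[C@H]2OC(C)=O)c1-c1cccs1`) keeps the sugar part of compound 2 and changes one place: thiophen-2-yl in place of iodo on an aromatic carbon, next to the ring atom that bears an ethoxycarbonyl group (thiophen-2-yl in place of iodo on an aromatic carbon). The expectation rests on compound 3, whose limit of > 10000 nM stands with a thiophen-2-yl group already present. A large gain in this assay is therefore not expected: the likely outcome is a small move towards stronger inhibition or none beyond the scatter. The expected step is a number no higher from compound 2 to compound 4 (the limit leaves the size open) and it is only a rough estimate. For compound 4 the estimated value is 10000 nM with an expected range from 2000 nM to 40000 nM overall.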

Compound 4, half-maximal inhibitory concentration: > 10000 nM
Compound 4 was reported as a limit; the forecaster's own chance of this, stated with the estimate: 65%; the middle value lies on the limit itself.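

Compound 4, like compound 2, is reported only as a limit, so the step between them, thiophen-2-yl in place of iodo, cannot be read. The compounds shown leave open whether any change to the shared core would give an exact value, since the picture remains: the limit of > 10000 nM in this assay, at which 4 of the 4 values shown sit.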